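From 3-bromobenzyl to 3-methoxybenzyl

A few compounds are considered here, and "the series" means these few. Any claim that something is new, unique, unknown or untested is made for them only; others in the source may bear on it.

In a functional assay on HL-60 cells (Homo sapiens) for antiproliferative activity, with a stated time of 72 h (a higher number here means a weaker inhibitor, a lower number a stronger inhibitor), compound 1 `OC[C@H]1O[C@@H](n2cnc3c(NCc4ccccc4Cl)ncnc32)[C@H](O)[C@@H]1O` gives 1600 nM, compound 2 `OC[C@H]1O[C@@H](n2cnc3c(NCc4ccccc4Br)ncnc32)[C@H](O)[C@@H]1O` gives 6600 nM and compound 3 `OC[C@H]1O[C@@H](n2cnc3c(NCc4cccc(Br)c4)ncnc32)[C@H](O)[C@@H]1O` gives 8000 nM. The measured steps are a 4.1-fold higher number from compound 1 to compound 2 (0.62 log units; beyond the scatter), a 5.0-fold higher number from compound 1 to compound 3 (0.70 log units; beyond the scatter) and a 1.2-fold higher number from compound 2 to compound 3 (0.08 log units; within the scatter). Only the last lies within the scatter, so compound 3 stands level with compound 2, and both are weaker than compound 1. Compound 4 `COc1cccc(CNc2ncnc3c2ncn3[C@@H]2O[C@H](CO)[C@@H](O)[C@H]2O)c1` carries methoxy in place of bromo on an aromatic carbon, (methoxy in place of bromo on an aromatic carbon). Within the data shown here, no measured compound carries methoxy, and the modest halogen exchange, a 4.1-fold higher number from compound 1 to compound 2 (0.62 log units; beyond the scatter), gives no direction for this change. The expected step, which stays within the scatter, is a 1.3-fold lower number from compound 3 to compound 4 (0.12 log units; within the scatter). For compound 4 the estimated value is 6000 nM, with an expected range of 2500 nM to 15000 nM.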

Compound 4, half-maximal inhibitory concentration: 4900 nM
Compound 4: middle estimate off by 1.2-fold (0.09 log units), on the high side, within the range that was stated.
By their numbers in this assay, from the lowest: compound 1; then compounds 4, 2 and 3 (each within the scatter of the next).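

Bromo and methoxy differ in heavy atoms and hydrogen-bond acceptors, yet on this aromatic carbon, meta to a large group, the exchange gives in this assay only a 1.6-fold lower number from compound 3 to compound 4 (0.21 log units; within the scatter) and so leaves the two compounds level. Compound 4 also stands level with the 2-bromophenyl compound, with a 1.3-fold lower number from compound 2 to compound 4 (0.13 log units; within the scatter), while a 3.1-fold higher number from compound 1 to compound 4 (0.49 log units; beyond the scatter) keeps compound 1 apart. No available evidence accounts for these steps. Going by these compounds, whether an amine or a carboxylic acid on this carbon would also stay level with compound 3 remains open, as does how methoxy would read in place of the chloro of compound 1.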